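Swapping 2-cyanoethyl for pyridin-4-yl on the carbonyl

A few compounds are considered here, and "the series" means these few. Any claim that something is new, unique, unknown or untested is made for them only; others in the source may bear on it.

In a physicochemical assay for solubility, measured as kinetic solubility, with a stated time of 1 h, at pH 7.4 (a lower number here means a less soluble compound, a higher number a more soluble compound), compound 1 (`NC1=NN(c2ccc(Cl)c(Cl)c2)CC1`) gives 69000 nM and compound 2 (`N#CCCC(=O)NC1=NN(c2ccc(Cl)c(Cl)c2)CC1`) gives 39000 nM, so the two lie within the scatter of each other. For the measured compounds named here, the one measured step, a 1.8-fold lower number from compound 1 to compound 2 (0.25 log units; within the scatter), is also the only guide, and it concerns a different change. Compound 3 (`O=C(NC1=NN(c2ccc(Cl)c(Cl)c2)CC1)c1ccncc1`) carries pyridin-4-yl in place of 2-cyanoethyl on a carbonyl carbon. Going by the values given here, no measured step covers this exchange, so only a small shift is expected. The estimated step, a 1.8-fold lower number from compound 2 to compound 3 (0.25 log units; within the scatter), leans toward a lower number. Compound 3 is expected at 22000 nM, with an estimated range of 7000 nM to 55000 nM.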

Compound 3, solubility: 9000 nM
Compound 3: the middle estimate sits 2.4-fold (0.39 log units) above what was measured; measured number inside the range.
By their numbers in this assay, from the lowest: compound 3; then compounds 2 and 1 (each within the scatter of the next).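

In this assay, for the compounds shown here, the group on the carbonyl carbon makes a readable difference: pyridin-4-yl in place of 2-cyanoethyl brings a 4.3-fold lower number from compound 2 to compound 3 (0.64 log units; beyond the scatter) and gives the first step beyond the scatter. The earlier step, a 1.8-fold lower number from compound 1 to compound 2 (0.25 log units; within the scatter) on the amine nitrogen, did not separate its two compounds. No measurement shown bears on the reason for the new step.

From the compounds shown here alone, whether the lower number goes with the ring as such or with the ring nitrogen of pyridin-4-yl stays open. Phenyl on the same carbonyl carbon would separate the two, and a longer chain or a carboxylic acid there would show how far the position tolerates other groups.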